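The source may hold more compounds than are shown below. What is called first, only, known or untested is meant among the compounds shown, and "the series" means these compounds.

Working notes on the series, read in an ADME assay on BJ cells (Homo sapiens) for cytotoxicity, read by MTT assay, with a stated time of 72 h; on this read-out lower numbers stand for stronger inhibition and higher numbers for weaker inhibition. Compound 1 `COc1ccc(CNc2ncnc3c2ncn3C2CCCCO2)cc1OC` gives > 100000 nM, which is a limit of the assay and not a number. Compound 2 `COc1ccc(CNc2ncnc3c2ncn3C2CCCCO2)c(OC)c1OC` gives > 37500 nM, which is also a limit. Within the data shown here, compound 1 therefore has no measured number as a starting point, and the only other value available offers none either. Compound 3 `COc1cc(CNc2ncnc3c2ncn3C2CCCCO2)cc(OC)c1OC` differs from compound 1 by methoxy in place of hydrogen on an aromatic carbon, ortho to a methoxy group. Among the measured compounds shown here, the one measured step of the same kind is a step that the two limits leave unreadable from compound 1 to compound 2. That step has no readable size, so it supports no expected direction, and no step beyond the scatter is expected in this assay. For compound 3 the estimated value is 100000 nM, with an expected range of 37500 nM to 200000 nM. The expected change is a number no higher from compound 1 to compound 3 (the limit leaves the size open).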

Compound 3, half-maximal inhibitory concentration: > 100000 nM
Compound 3 ended at the assay's limit (the forecaster's own chance of this, stated with the estimate: 75%); the middle value sits exactly at the limit.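

Compound 1 and compound 3 both sit at a limit in this assay, so the step between them cannot be read. The compounds shown leave open whether methoxy in place of hydrogen on an aromatic carbon shifts this read-out at all, and where compound 1, compound 2 and compound 3 would give an actual number.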